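This account rests on a few compounds, and the source may have more. Where it says the series, first, only, none or still open, it means among the compounds named here.

Measured compounds:
compound 1 `COC(=O)N[C@H](C(=O)N1CCC[C@H]1C(=O)Nc1ccc([C@@H]2CC[C@@H](c3ccc(NC(=O)[C@@H]4CCCN4C(=O)[C@@H](NC(=O)OC)[C@H]4CCOC4)cc3)N2c2ccc(F)cc2)cc1)[C@H]1CCOC1` gives 9700 nM in a physicochemical assay for solubility, in phosphate buffer, measured as kinetic solubility, at pH 7.2; a higher number here means a more soluble compound, a lower number a less soluble compound;
compound 2 `COC(=O)N[C@H](C(=O)N1CCC[C@H]1C(=O)Nc1ccc([C@@H]2CC[C@@H](c3ccc(NC(=O)[C@@H]4CCCN4C(=O)[C@@H](NC(=O)OC)C(C)C)cc3)N2c2ccc(F)cc2)cc1)C(C)C` gives 4100 nM in this assay.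

Among the compounds with values here, compound 1 thus stands highest of the two numbers, with compound 2 its only neighbour, a gap that lies beyond the scatter. Compound 3 `COC(=O)N[C@H](C(=O)N1CCC[C@H]1C(=O)Nc1ccc([C@H]2CC[C@H](c3ccc(NC(=O)[C@@H]4CCCN4C(=O)[C@@H](NC(=O)OC)[C@H]4CCOC4)cc3)N2c2ccc(F)cc2)cc1)[C@H]1CCOC1` differs from compound 1 only in configuration: the two compounds have the same atoms and bonds and differ only in configuration as drawn: 2 of 8 stereo elements differ; a stereocentre at a saturated ring carbon is drawn S in compound 1 and R in compound 3; a stereocentre at a saturated ring carbon is drawn S in compound 1 and R in compound 3. Within the data shown here, no measured pair shows what such a flip of two ring centres does here. With no direction to lean on, compound 3 is expected to stay close to compound 1, the step of a 1.1-fold lower number from compound 1 to compound 3 (0.06 log units; within the scatter) judged to be within the scatter. Compound 3 is therefore estimated at 8500 nM, ranging from 3000 nM to 24000 nM.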

Compound 3, solubility: 8500 nM
The estimate for compound 3 equals the measured number at the digits printed; low and high end bracket the measured number.
By their numbers in this assay, from the lowest: compound 2; then compounds 3 and 1 (each within the scatter of the next).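

In this assay, the flip of two stereocentres at saturated ring carbons from S to R comes with a 1.1-fold lower number from compound 1 to compound 3 (0.06 log units; within the scatter), so this pair shows that the drawn configuration at these two centres leaves the read-out within the scatter. Within the data shown here, it is the first pair here that differs in one place, so the step can be read on configuration alone: the fact that compounds 1 and 3 differ only in the configuration as drawn.

On these data alone, whether the same flip stays within the scatter on compound 2, or when only one of the two centres is inverted, remains open. So does the effect of an amine or a carboxylic acid on the shared core.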